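Sulfonamide to methyltetrazole on the anilide core

The compounds below may be only part of what the source reports. "The series", "measured", "known", "first", "only" and "open" are said of these compounds alone.

Measured compounds:
compound 1 `CC(O)(C(=O)Nc1ccc(-c2nn[nH]n2)cc1)C(F)(F)F` — > 30000 nM
compound 2 `CC(O)(C(=O)Nc1ccc(S(N)(=O)=O)cc1)C(F)(F)F` — 12800 nM
compound 3 `CC(O)(C(=O)Nc1ccc(S(=O)(=O)N2CCCCC2)cc1)C(F)(F)F` — 9250 nM

In an assay on a protein complex (Cavia porcellus) with sulfonylurea receptors; K-ATP channels (Homo sapiens) as the target (a higher number here means a weaker inhibitor, a lower number a stronger inhibitor), compound 1 gives > 30000 nM, which is a limit of the assay rather than a number. Within the data shown here, compound 2 and compound 3 are the only compounds with numbers; they differ by a 1.4-fold lower number from compound 2 to compound 3 (0.14 log units; within the scatter), so neither stands apart from the other. Compound 4 `Cn1nnnc1-c1ccc(NC(=O)C(C)(O)C(F)(F)F)cc1` has not been measured; it differs from compound 2 as follows (1-methyl-1H-tetrazol-5-yl in place of sulfamoyl on an aromatic carbon).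

Among the measured compounds shown here, the step that bears on this change is the one between compound 1 and compound 2, where a sulfamoyl group replaced a 2H-tetrazol-5-yl group and the number moved by an at least 2.3-fold lower number from compound 1 to compound 2 (0.36 log units; beyond the scatter). Compound 4 returns a tetrazolyl group to the same aromatic carbon, now carrying a methyl, so a move back toward a higher number is expected, roughly a 2.0-fold higher number from compound 2 to compound 4 (0.29 log units; within the scatter), with a real chance that only a limit is reported. Compound 4 is therefore estimated at 25000 nM, within 9000 nM to 70000 nM.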

Compound 4, half-maximal inhibitory concentration: 30900 nM
For compound 4 the middle estimate is 1.2-fold (0.09 log units) below the measured one; low and high end bracket the measured number.
By their numbers in this assay, from the lowest: compounds 3 and 2 (each within the scatter of the next); then compound 4.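

In this assay, the change from sulfamoyl to 1-methyl-1H-tetrazol-5-yl on this aromatic carbon gives a 2.4-fold higher number from compound 2 to compound 4 (0.38 log units; beyond the scatter), so a tetrazole at this position now has a measured number and a step beyond the scatter from the sulfonamide. The sulfonamide therefore holds its advantage over a tetrazole here in a step that can be sized on both sides, which the earlier comparison could not offer. Compound 1 carries only a limit, so the step from compound 1 to compound 4 cannot be read: the limit of > 30000 nM in this assay, at which 1 of the 4 values shown sits.

From the compounds shown here alone, whether the methyl on the tetrazole changes the number at all therefore stays open. Also open, going by these compounds, is where a carboxylic acid, a nitrile or a primary amide on the same aromatic carbon would fall relative to compound 2 and compound 4.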